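Replacing a propyl chain with phenyl on the shared core

A few compounds are considered here, and "the series" means these few. Any claim that something is new, unique, unknown or untested is made for them only; others in the source may bear on it.

Measured compounds:
compound 1 `CCCC[C@H](CCn1cncn1)c1ccc(OC)cc1`: 34.5 ug/mL
compound 2 `CCCC[C@@H](CCn1cncn1)c1ccc(OC)cc1`: 31.6 ug/mL
compound 3 `CCCC[C@@H](CCn1cncn1)c1ccc(C)cc1`: 60.7 ug/mL

All three compounds were tested in an ADME assay on HEp-2 cells (Homo sapiens) for cytotoxicity, read by MTT assay, with a stated time of 3 days; on this read-out lower numbers stand for higher toxicity in this test and higher numbers for lower toxicity in this test. Compound 2 gives the lowest of the three numbers there, yet its neighbours sit close: compound 1 lies a step of a 1.1-fold lower number from compound 1 to compound 2 (0.04 log units; within the scatter) away, and compound 3 a step of a 1.9-fold higher number from compound 2 to compound 3 (0.28 log units; within the scatter) away, so the three values cannot be told apart. The step from compound 1 to compound 2 rests on the fact that compounds 1 and 2 differ only in the configuration as drawn alone.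

Compound 4 `COc1ccc([C@H](CCn2cncn2)Cc2ccccc2)cc1` has not yet been measured. Compared with compound 2 it carries phenyl in place of propyl on a saturated chain carbon, two bonds along the chain from an aromatic carbon. Neither measured step touches this kind of change: one swaps the drawn configuration at the chain carbon, the other swaps methyl for methoxy on the aromatic ring, and both stayed within the scatter. They therefore give no direction for an exchange of a chain for an aromatic ring, and the expectation is simply a number near that of compound 2, with a wider range than usual.

The estimated step from compound 2 to compound 4 in this assay is a 1.1-fold lower number from compound 2 to compound 4 (0.02 log units; within the scatter). Compound 4 is therefore expected to give about 30 ug/mL in this assay, somewhere between 12 ug/mL and 75 ug/mL.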

Compound 4, half-maximal cytotoxic concentration: 60.3 ug/mL
Compound 4: middle estimate off by 2.0-fold (0.30 log units), on the low side, and the stated range covers the measured number.
By their numbers in this assay, from the lowest: compounds 2, 1, 4 and 3 (each within the scatter of the next).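

In this assay, the exchange at this position gives a 1.9-fold higher number from compound 2 to compound 4 (0.28 log units; within the scatter), so this step stays within the scatter, as the earlier ones did. What is new is that the chain itself is changed: an open propyl gives way to phenyl, a six-membered aromatic ring, on a saturated chain carbon, two bonds along the chain from an aromatic carbon, and the number still cannot be told apart from that of compound 2. Nothing at hand bears on why this exchange gives so small a step.

From the compounds shown here alone, whether an amine, a carboxylic acid or a longer chain such as octyl at this position would also stay within the scatter remains open. Going by these compounds, it also remains open whether the opposite drawn configuration at the chain carbon would read alike with phenyl in place.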